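This account rests on a few compounds, and the source may have more. Where it says the series, first, only, none or still open, it means among the compounds named here.

Compound 1 `COc1ncnc2c1c(-c1ccsc1)cn2[C@@H]1O[C@H](CO)[C@@H](O)[C@H]1O` gives 3350 nM in a functional assay on HeLa S3 cells (Homo sapiens) for antiproliferative activity, read by XTT assay, with a stated time of 72 h; a lower number here means a stronger inhibitor, a higher number a weaker inhibitor. Compound 2 `COc1nc(N)nc2c1c(-c1ccsc1)cn2[C@@H]1O[C@H](CO)[C@@H](O)[C@H]1O` carries amino in place of hydrogen on an aromatic carbon, and in this assay compound 2 reaches only a limit of > 20000 nM, the limit described as the limit of > 20000 nM in this assay, at which 1 of the 3 values shown sits. That change produced an at least 5.9-fold higher number from compound 1 to compound 2 (0.77 log units; beyond the scatter). Compound 3 `O=c1[nH]cnc2c1c(-c1ccco1)cn2[C@@H]1O[C@H](CO)[C@@H](O)[C@H]1O` gives 5780 nM in this assay; the difference between the core of compound 1 and the core of compound 3 is not broken down here. Compound 4 `Nc1nc2c(c(-c3ccco3)cn2[C@@H]2O[C@H](CO)[C@@H](O)[C@H]2O)c(=O)[nH]1` carries amino in place of hydrogen on an aromatic carbon, the same kind of change, although here the place is meta to a group of 1 heavy atom rather than meta to a methoxy group (2 heavy atoms). Resting on an at least 5.9-fold higher number from compound 1 to compound 2 (0.77 log units; beyond the scatter), the step from compound 3 to compound 4 is expected to be a 4.8-fold higher number from compound 3 to compound 4 (0.69 log units; beyond the scatter). Compound 4 is therefore estimated at 28000 nM, between 9000 nM and 90000 nM.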

Compound 4, half-maximal inhibitory concentration: > 20000 nM
Compound 4 gave a limit, no number; the forecaster's own chance of this, stated with the estimate: 60%; the middle value does not contradict the limit.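

In this assay, amino in place of hydrogen on an aromatic carbon again gives a weaker compound, with an at least 3.4-fold higher number from compound 3 to compound 4 (0.53 log units; beyond the scatter). Compound 4 gives > 20000 nM, which is a limit of the assay and not a number. The direction of the change therefore carries over from one core to the other, but the compounds cannot show whether its size does too: the same change on two cores in this assay, an at least 5.9-fold higher number (0.77 log units; beyond the scatter) from compound 1 to compound 2 and an at least 3.4-fold higher number (0.53 log units; beyond the scatter) from compound 3 to compound 4; the limit leaves it open whether they differ

On these data alone, how weak compound 2 and compound 4 really are stays open: the limit of > 20000 nM in this assay, at which 2 of the 4 values shown sit. Also open is what another small group on this aromatic carbon, such as methyl, chlorine or a dimethylamino group, would do on either core.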